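The source may report more compounds than this note shows. Statements on the series, on what has been measured and on what is new or still open speak of the compounds shown alone.

Values in a functional assay on B16-F10 cells (Mus musculus) for antiproliferative activity, read by MTT assay, with a stated time of 48 h (a lower number here means a stronger inhibitor, a higher number a weaker inhibitor), so far:
compound 1 `CCCCCCCCCCCCOc1ccc(C(=O)/C=C/c2c(/C=C/c3ccc(OC)cc3)cc(OC)cc2OC)cc1` gives 12.7 ug/mL
compound 2 `COc1ccc(/C=C/c2cc(OC)cc(OC)c2/C=C/C(=O)c2ccc(Br)cc2)cc1` gives 6.5 ug/mL
compound 3 `COc1ccc(/C=C/c2cc(OC)cc(OC)c2/C=C/C(=O)c2ccc(C)cc2C)cc1` gives 4 ug/mL

Compound 3 at 4 ug/mL lies within the scatter of compound 2 and beyond the scatter from compound 1, which shows the higher number. Compound 4 `COc1ccc(/C=C/c2cc(OC)cc(OC)c2/C=C/C(=O)c2ccc(OC)cc2)cc1` is not yet measured. Its difference from compound 3 is 4-methoxyphenyl in place of 2,4-dimethylphenyl on a carbonyl carbon and reads 4-methoxyphenyl in place of 2,4-dimethylphenyl on a carbonyl carbon. For the measured compounds named here, the only measured step at this place is a 1.6-fold lower number from compound 2 to compound 3 (0.21 log units; within the scatter) and it stays within the scatter. No step beyond the scatter is therefore expected in this assay here. The estimate means a 1.4-fold higher number from compound 3 to compound 4 (0.14 log units; within the scatter) as the expected step. Compound 4 is expected at 5.5 ug/mL with an estimated range from 2.5 ug/mL to 12 ug/mL as its upper end.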

Compound 4, half-maximal inhibitory concentration: 5.8 ug/mL
The estimate for compound 4 lay 1.1-fold (0.02 log units) below the measured number; low and high end bracket the measured number.
By their numbers in this assay, from the lowest: compounds 3, 4, 2 and 1 (each within the scatter of the next, the first and the last beyond it).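

In this assay, methoxy in place of bromo on an aromatic carbon (a 1.1-fold lower number from compound 2 to compound 4 (0.05 log units; within the scatter)) and 4-methoxyphenyl in place of 2,4-dimethylphenyl on a carbonyl carbon (a 1.5-fold higher number from compound 3 to compound 4 (0.16 log units; within the scatter)) both stay within the scatter, so these three aryl groups are not told apart. Hydrogen in place of undecyl on the saturated chain carbon bound to an oxygen on an aromatic ring gives the only new step beyond the scatter, and a modest one (a 2.2-fold lower number from compound 1 to compound 4 (0.34 log units; beyond the scatter)). No evidence is available to explain these steps.

Going by these compounds, whether an amine or a carboxylic acid on the aryl ring would give a step beyond the scatter remains open. So does how a hexyl chain on that oxygen would read.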